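Swapping methylamino for methoxymethyl on a biaryl edge

This account rests on a few compounds, and the source may have more. Where it says the series, first, only, none or still open, it means among the compounds named here.

Measured compounds:
- compound 1, `CCOc1ccccc1-c1ccc(-c2nc(NC(C)C(=O)O)c3ccncc3n2)cc1`, 2.1
- compound 2, `CCOc1ccccc1-c1ccc(-c2nc3cnccc3c(NC(C(N)=O)C3CC3)c2C#N)cc1`, 3
- compound 3, `CC[C@@H](Nc1c(C#N)c(-c2ccc(-c3ccccc3NC)cc2)nc2cnccc12)C(N)=O`, 2.5

Of the compounds shown here, three have been read in a physicochemical assay for lipophilicity, read by HPLC, at pH 7.5; on this read-out higher numbers stand for higher lipophilicity and lower numbers for lower lipophilicity. In this assay compound 1 gives 2.1, compound 2 gives 3 and compound 3 gives 2.5. Compound 3 therefore stands second highest of the three: its number lies above that of compound 1 and below that of compound 2, and both gaps are wider than the usual scatter of repeated readings.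

Compound 4, `CC[C@@H](Nc1c(C#N)c(-c2ccc(-c3ccccc3COC)cc2)nc2cnccc12)C(N)=O`, has not yet been measured. Compared with compound 3, one group on the outer benzene ring is exchanged: methoxymethyl in place of methylamino on an aromatic carbon. The leaving group carries a hydrogen-bond donor; the entering group carries none and is one heavy atom larger.

Going by the values given here, no measured pair shows this exact change, so the expectation rests on the size of the groups alone. The step from compound 3 to compound 4 is expected to be small and upward, a number 0.30 log units higher from compound 3 to compound 4 (within the scatter). Compound 4 is estimated at 2.8, within a range from 2.4 to 3.2.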

Compound 4, distribution coefficient: 2.6
For compound 4 the middle estimate is 0.20 log units above the measured one, within the range that was stated.
By their numbers in this assay, from the lowest: compound 1; then compounds 3 and 4 (each within the scatter of the next); then compound 2.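

In this assay, putting methoxymethyl in place of methylamino on an aromatic carbon, ortho to a large group, gives a number 0.10 log units higher from compound 3 to compound 4 (within the scatter). Going by these compounds alone, this is the first pair that differs in one place, and it shows that at this position a group with no hydrogen-bond donor can replace one that carries a donor without a difference that can be told from the scatter of repeated readings. Nothing measured here explains this result.

A single pair cannot show whether other groups at this position, such as a carboxylic acid, a primary amine or a longer ether chain, would read the same way. It also leaves open whether the same exchange would give a similar step on another compound, where the rest of the molecule differs.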